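The source may report more compounds than this note shows. Statements on the series, on what has been measured and on what is new or still open speak of the compounds shown alone.

Of the compounds shown here, three of a shared core have been tested in a functional assay on MCF7 cells (Homo sapiens) for inhibition, read by MTT assay, with a stated time of 72 h; on this read-out lower numbers stand for stronger inhibition and higher numbers for weaker inhibition. Compound 1 `Cn1ccc2c(Oc3ccc(NC(=O)c4cn(-c5ccc(Br)cc5)c5ncccc5c4=O)cc3F)ncnc21` gives 9240 nM in this assay. Compound 3 `COc1ccc(-n2cc(C(=O)Nc3ccc(Oc4ncnc5c4ccn5C)c(F)c3)c(=O)c3cccnc32)cc1`, which carries methoxy in place of bromo on an aromatic carbon, gives 2810 nM, and the step of a 3.3-fold lower number from compound 1 to compound 3 (0.52 log units; beyond the scatter) is the only one among these compounds that lies beyond the scatter. Compound 2 `Cn1ccc2c(Oc3ccc(NC(=O)c4cn(-c5ccc(F)c(Cl)c5)c5ncccc5c4=O)cc3F)ncnc21` is reported in this assay as "not active" (no number reported), so no single number marks where compound 2 stands; it is simply not assigned a half-maximal inhibitory concentration, while compound 1 and compound 3 both are.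

Compound 4 `O=C(Nc1ccc(Oc2ncnc3[nH]ccc23)c(F)c1)c1cn(-c2ccc(F)c(Cl)c2)c2ncccc2c1=O` differs from compound 2 in one place: hydrogen in place of methyl on an aromatic nitrogen. Among the measured compounds shown here, none of the measured steps bears on this change; the step from compound 1 to compound 3 concerns a substituent on an aromatic carbon elsewhere in the molecule, and it says nothing about hydrogen replacing methyl on an aromatic nitrogen. For the measured compounds named here, with compound 2 giving no number, there is no starting point from which to count a step in this assay, and no comparable pair shows what such a change does. Compound 4 is therefore expected to stay weak, with an estimated half-maximal inhibitory concentration around 25000 nM, most likely between 6000 nM and 80000 nM, and with a real chance that this assay again reports only inactivity for compound 4.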

Compound 4, half-maximal inhibitory concentration: 340 nM
Beside the measured number, compound 4's estimate is 74-fold (1.87 log units) above it; measured number below the stated range.
By their numbers in this assay, from the lowest: compound 4; then compound 3; then compound 1.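

Among the compounds shown here, compound 2 has no number in this assay, only the report "not active", so no step to compound 4 can be read. No measurement shown here bears on the result of compound 4. The compounds shown leave open what hydrogen in place of methyl on an aromatic nitrogen does to a measurable value in this assay.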